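The compounds below may be only part of what the source reports. "The series", "measured", "known", "first", "only" and "open" are said of these compounds alone.

In a functional assay on B16-F10 cells (Mus musculus) for antiproliferative activity, read by CCK-8 assay, with a stated time of 48 h (a lower number here means a stronger inhibitor, a higher number a weaker inhibitor), compound 1 (`COc1ccc(/C=C\c2cc(OC)c(OC)c(OC)c2)cc1OCc1ccc(C=O)cc1`) gives 4200 nM and compound 2 (`COc1ccc(/C=C\c2cc(OC)c(OC)c(OC)c2)cc1OCc1ccc(CNCCO)cc1`) gives 6600 nM, so compound 2 stands level with compound 1 within the scatter. Compound 3 (`COc1ccc(/C=C\c2cc(OC)c(OC)c(OC)c2)cc1OCc1ccc(CN2CC[C@H](C(=O)O)C2)cc1`) is unmeasured. It differs from compound 2 by 3-carboxypyrrolidin-1-yl in place of (2-hydroxyethyl)amino on a saturated chain carbon bound to an aromatic carbon. For the measured compounds named here, the only measured step, a 1.6-fold higher number from compound 1 to compound 2 (0.20 log units; within the scatter), replaced formyl with ((2-hydroxyethyl)amino)methyl on an aromatic carbon. Going by the values given here, no measured compound carries 3-carboxypyrrolidin-1-yl, so this evidence is thin, and no step beyond the scatter is expected in this assay. For compound 3, the estimated value is 7000 nM, with an expected range of 2500 nM to 20000 nM. This estimate means an expected 1.1-fold higher number from compound 2 to compound 3 (0.03 log units; within the scatter).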

Compound 3, half-maximal inhibitory concentration: 7000 nM
Compound 3: the middle estimate sits on the measured number at the digits printed; measured number inside the range.
By their numbers in this assay, from the lowest: compounds 1, 2 and 3 (each within the scatter of the next).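

In this assay, a larger ring-bearing group with a carboxyl function, 3-carboxypyrrolidin-1-yl, on the saturated chain carbon bound to an aromatic carbon reads level with (2-hydroxyethyl)amino, with a 1.1-fold higher number from compound 2 to compound 3 (0.03 log units; within the scatter). The formyl compound also stays level, with a 1.7-fold higher number from compound 1 to compound 3 (0.22 log units; within the scatter), so this assay does not separate the three groups at this site. Nothing measured here offers an explanation for these steps. Still open, from the compounds shown here alone, is whether the opposite enantiomer of 3-carboxypyrrolidin-1-yl, a piperidine ring, a dimethylamino group or an open-chain carboxylic acid would read any differently.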